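Taking the fluoro group off compound 3

The compounds below may be only part of what the source reports. "The series", "measured", "known", "first", "only" and "open" are said of these compounds alone.

Measured in a functional assay on MCF7 cells (Homo sapiens) for antiproliferative activity, read by CellTiter-Glo, with a stated time of 5 days (a higher number here means a weaker inhibitor, a lower number a stronger inhibitor), so far:
- compound 1 `CC1=C(c2ccc(S(C)(=O)=O)cc2)C(c2ccc(OC[C@H](C)N3CC[C@@H](C)C3)cc2)Oc2ccc(O)cc21` gives 27 nM
- compound 2 `CC1=C(c2cccc(S(C)(=O)=O)c2)C(c2ccc(OC[C@H](C)N3CC[C@@H](C)C3)cc2)Oc2ccc(O)cc21` gives 4.3 nM
- compound 3 `CC1=C(c2ccc(F)cc2)C(c2ccc(OC[C@H](C)N3CC[C@@H](C)C3)cc2)Oc2ccc(O)cc21` gives 0.4 nM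

Compound 3 has the lowest number of the three in this assay and is the strongest inhibitor here. Compound 4 `CC1=C(c2ccccc2)C(c2ccc(OC[C@H](C)N3CC[C@@H](C)C3)cc2)Oc2ccc(O)cc21` has hydrogen in place of fluoro on an aromatic carbon, para to a large group hydrogen in place of fluoro on an aromatic carbon and is still unmeasured. Two large steps lead to compound 3 (a 68-fold lower number from compound 1 to compound 3 (1.83 log units; beyond the scatter); an 11-fold lower number from compound 2 to compound 3 (1.03 log units; beyond the scatter)), with a modest one between the sulfones (a 6.3-fold lower number from compound 1 to compound 2 (0.80 log units; beyond the scatter)). All of them involve methylsulfonyl, and none compares hydrogen with fluoro. They therefore set no size for this change, and no shift beyond the scatter is expected in this assay, with at most a slight rise. The expected step is small (a 1.5-fold higher number from compound 3 to compound 4 (0.18 log units; within the scatter)). Compound 4 is estimated at 0.6 nM (expected range 0.2 nM to 2 nM).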

Compound 4, half-maximal inhibitory concentration: 0.4 nM
Estimate against measurement, compound 4: 1.5-fold (0.18 log units) above; low and high end bracket the measured number.
By their numbers in this assay, from the lowest: compounds 3 and 4 (each within the scatter of the next); then compound 2; then compound 1.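

In this assay, hydrogen in place of fluoro gives no measurable shift (no change at the digits printed from compound 3 to compound 4 (within the scatter)), so the low number at this aromatic carbon does not depend on fluoro. Among the compounds shown here, the unsubstituted phenyl also gives the first direct comparison with each sulfone (an 11-fold lower number from compound 2 to compound 4 (1.03 log units; beyond the scatter); a 68-fold lower number from compound 1 to compound 4 (1.83 log units; beyond the scatter)), and both steps lie beyond the scatter, so the gaps to the sulfones do not depend on fluoro either. No available data explain these steps.

Open, as far as these compounds go, is how other groups behave at this carbon, for example an amine or a carboxylic acid. Between hydrogen and methylsulfonyl, the compounds shown offer no intermediate case.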